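The source may hold more compounds than are shown below. What is called first, only, known or untested is meant among the compounds shown, and "the series" means these compounds.

Measured so far in a functional assay on MDA-MB-468 cells (Homo sapiens) for inhibition, read by sulforhodamine B assay, with a stated time of 48 h; on this read-out higher numbers stand for weaker inhibition of growth and lower numbers for stronger inhibition of growth:
compound 1 `CN1CCN(CCCOc2cccc3nc(Nc4ccc(Cl)c(F)c4)ccc23)CC1`, 1720 nM
compound 2 `CN1CCN(CCCOc2cccc3nc(Nc4cc(Cl)cc(Cl)c4)ccc23)CC1`, 1690 nM

Compound 2 stands alongside compound 1; the step of a 1.0-fold lower number from compound 1 to compound 2 (0.01 log units; within the scatter) separates nothing. Compound 3 `CN1CCN(CCCOc2cccc3nc(Nc4cccc(Cl)c4)ccc23)CC1` differs from compound 2 by hydrogen in place of chloro on an aromatic carbon. Within the data shown here, no measured step removes a halogen from this ring. Among the measured compounds shown here, the only step on hand, a 1.0-fold lower number from compound 1 to compound 2 (0.01 log units; within the scatter), swaps one halogenated phenyl for another and stays within the scatter, so a change in this assay of no size beyond the scatter is expected, leaning if anything toward a higher number, as a 1.4-fold higher number from compound 2 to compound 3 (0.13 log units; within the scatter). Compound 3 is estimated at 2300 nM, range 900 nM to 6000 nM.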

Compound 3, concentration for 50% growth inhibition: 1610 nM
Compound 3: the middle estimate sits 1.4-fold (0.15 log units) above what was measured, within the range that was stated.
By their numbers in this assay, from the lowest: compounds 3, 2 and 1 (each within the scatter of the next).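

In this assay, hydrogen in place of chloro on this aromatic carbon gives no change beyond the scatter (a 1.0-fold lower number from compound 2 to compound 3 (0.02 log units; within the scatter)), so the second chloro of the 3,5-dichlorophenyl group is not needed to keep the value in this band. The 3-chlorophenyl and 4-chloro-3-fluorophenyl groups also lie within the scatter of each other (a 1.1-fold lower number from compound 1 to compound 3 (0.03 log units; within the scatter)). Nothing at hand explains this flat response.

From the compounds shown here alone, all three compounds carry a chloro on this ring, so plain phenyl remains open. So do an amine or a carboxylic acid on the ring in place of chloro.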